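This account rests on a few compounds, and the source may have more. Where it says the series, first, only, none or still open, it means among the compounds named here.

Measured in a functional assay on Huh-7 cells (Homo sapiens) for cytotoxicity, read by MTT assay, with a stated time of 72 h; on this read-out higher numbers stand for lower toxicity in this test and lower numbers for higher toxicity in this test:
Compound 1 `CCS(=O)(=O)N1CCC2(CC1)OOC1(CCCC1)OO2`: > 100 ug/mL
Compound 2 `CCCCS(=O)(=O)N1CCC2(CC1)OOC1(CCCC1)OO2`: > 100 ug/mL
Compound 3 `Cc1ccc(S(=O)(=O)N2CCC3(CC2)OOC2(CCCC2)OO3)cc1`: > 100 ug/mL

Compound 3 stands at > 100 ug/mL, which is a limit and not a number. The whole series looks the same: the limit of > 100 ug/mL in this assay, at which 3 of the 3 values shown sit. Compound 4 `O=S(=O)(c1ccc(F)cc1)N1CCC2(CC1)OOC1(CCCC1)OO2` keeps the shared core and differs by one group: fluoro in place of methyl on an aromatic carbon. The measured steps that bear on this are a step that the two limits leave unreadable from compound 2 to compound 3 and a step that the two limits leave unreadable from compound 1 to compound 3, both changes on the sulfonyl sulfur, and neither has a readable size. a step that the two limits leave unreadable from compound 1 to compound 2 adds no size either. The expected step that the limit leaves unreadable from compound 3 to compound 4 is therefore none beyond the scatter, with no direction favoured. For compound 4 the estimate is 120 ug/mL, with an expected range from 60 ug/mL to 250 ug/mL, and a report of only a limit is likely.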

Compound 4, half-maximal cytotoxic concentration: > 100 ug/mL
Compound 4: only a limit was reported; the forecaster's own chance of this, stated with the estimate: 85%; the middle value does not contradict the limit.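

The result for compound 4 is also only a limit, so no step from compound 1, compound 2 or compound 3 to compound 4 can be read: the limit of > 100 ug/mL in this assay, at which 4 of the 4 values shown sit.

Left open is the concentration at which any of these four compounds becomes toxic to the cells, and whether they differ at all.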